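Swapping furan-2-yl for phenethyl on the shared core

The compounds below may be only part of what the source reports. "The series", "measured", "known", "first", "only" and "open" are said of these compounds alone.

Compound 2 `O=C(Nn1c(-c2cccc([N+](=O)[O-])c2)nc2c(-c3ccco3)n[nH]c2c1=O)c1cccnc1` gives the lowest of the three numbers in a functional assay on HT-29 cells (Homo sapiens) for cytotoxicity, read by sulforhodamine B assay, with a stated time of 2 days, tested at 100 uM (on this read-out higher numbers stand for more inhibition at the one concentration tested (going by the name of the read-out) and lower numbers for less inhibition), at 11.7%. Compound 3 `COc1cccc(-c2nc3c(-c4ccco4)n[nH]c3c(=O)n2NC(=O)c2cccnc2)c1` lies nearest, at 12.8%, and the step of a number 1.1 percentage points higher from compound 2 to compound 3 (within the scatter) is within the scatter. Compound 1 `COc1cccc(-c2nc3c(-c4ccc(Cl)cc4)n[nH]c3c(=O)n2NC(=O)c2ccncc2)c1` stands furthest, at 46%; it differs from compound 3 in two places, so its value cannot be assigned to either change alone. Compound 4 `O=C(Nn1c(-c2cccc([N+](=O)[O-])c2)nc2c(CCc3ccccc3)n[nH]c2c1=O)c1cccnc1` carries phenethyl in place of furan-2-yl on an aromatic carbon. Going by the values given here, no measured step touches that part of the shared core, so these numbers set no direction for the change. Compound 4 is therefore estimated at 15%, with a range from 0% to 45%. The expected step of a number 3.3 percentage points higher from compound 2 to compound 4 (within the scatter) would stay within the scatter.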

Compound 4, a percentage reported as inhibition, at one concentration (the size of the read-out at that concentration, not a potency): 20.1%
Estimate against measurement, compound 4: 5.1 percentage points below; the measured number falls inside the stated range.
By their numbers in this assay, from the lowest: compounds 2, 3 and 4 (each within the scatter of the next); then compound 1.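

In this assay, going by these compounds alone, phenethyl in place of furan-2-yl on this aromatic carbon gives the first readable step at this position, a step of a number 8.4 percentage points higher from compound 2 to compound 4 (within the scatter), so for this one pair, the all-carbon group leaves the number within the scatter. This shows that the position can carry phenethyl with no change beyond the scatter, though it sets no trend. No measurement at hand explains the step. Still open, as far as these compounds go, is whether a shorter benzyl chain, or a chain ending in an amine or a carboxylic acid, would behave likewise at this position.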